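Swapping an Amide Chain for a Thiazolylamino Group

The compounds below may be only part of what the source reports. "The series", "measured", "known", "first", "only" and "open" are said of these compounds alone.

Measured so far in an ADME assay on microsomes from liver (Rattus norvegicus) for metabolic stability; a higher number here means that the compound lasts longer, a lower number that the compound disappears faster:
compound 1 `CC(C)C(c1nnc[nH]1)c1ccc(-c2ccc3cccc(F)c3c2)[nH]c1=O` gives 0.552 h
compound 2 `CC(C)NC(=O)CC(c1ccc(-c2ccc3cccc(F)c3c2)[nH]c1=O)C(C)C` gives < 0.0667 h

Compound 2 stands at the bottom of what has been measured. Its result is a limit of this assay rather than a number, because the compound disappears before the first reading (the limit of < 0.0667 h in this assay, at which 1 of the 2 values shown sits). Among the compounds with values here, the only measured step so far is an at least 8.2-fold lower number from compound 1 to compound 2 (0.91 log units; beyond the scatter), where the (isopropylcarbamoyl)methyl group took the place of a five-membered aromatic ring on the shared core.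

The next compound, compound 3 `CC(C)C(Nc1nccs1)c1ccc(-c2ccc3cccc(F)c3c2)[nH]c1=O`, moves in the opposite direction: (1,3-thiazol-2-yl)amino in place of (isopropylcarbamoyl)methyl on a saturated chain carbon bound to an aromatic carbon and a saturated chain carbon. The group that enters is again a small aromatic heterocycle attached through a single linking atom, which brings compound 3 closer in kind to compound 1 than to compound 2.

The step of an at least 8.2-fold lower number from compound 1 to compound 2 (0.91 log units; beyond the scatter) is the one that bears on this change, and it was large. Compound 3 is therefore expected to recover much of that loss, with an estimated rise of an at least 4.4-fold higher number from compound 2 to compound 3 (0.65 log units; beyond the scatter). The estimated half-life of compound 3 in this assay is 0.3 h, with a likely range from 0.08 h to 1 h.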

Compound 3, half-life: 0.07 h
The estimate for compound 3 lay 4.3-fold (0.63 log units) above the measured number; measured number outside the range, below it.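

Compound 3 shows that a small aromatic heterocycle on this saturated chain carbon does not by itself hold on to the longer half-life of compound 1: in this assay, (1,3-thiazol-2-yl)amino in place of 4H-1,2,4-triazol-3-yl gives a 7.9-fold lower number from compound 1 to compound 3 (0.90 log units; beyond the scatter). The change from the (isopropylcarbamoyl)methyl group gives an at least 1.0-fold higher number from compound 2 to compound 3 (0.02 log units; that floor lies within the scatter), so no gain can be read from it, and the half-life recovered only with the triazole of compound 1, not with every ring at this place. The value of compound 2, < 0.0667 h, is a limit and not a number, so the true gap to compound 3 stays unknown: the limit of < 0.0667 h in this assay, at which 1 of the 3 values shown sits.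

The thiazole of compound 3 and the triazole of compound 1 differ both in the ring and in the amino link, and the compounds shown leave open which of the two accounts for the step. A 1,3-thiazol-2-yl group bound directly to the chain carbon, or a (4H-1,2,4-triazol-3-yl)amino group, would pull these apart, and a plain amine at this place would show what any ring adds.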